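Swapping the Triazole Aryl Group: Compound 2 to Compound 4

A few compounds are considered here, and "the series" means these few. Any claim that something is new, unique, unknown or untested is made for them only; others in the source may bear on it.

Compound 1 `C=C1C[C@]23C[C@@]1(O)CC[C@@H]2c1cccc(C)c1[C@@H]3Cn1cc(-c2ccc(C)cc2)nn1` reaches only the limit > 20000 nM in a functional assay on HL-60 cells (Homo sapiens) for cytotoxicity, read by MTT assay, with a stated time of 4 days; on this read-out higher numbers stand for weaker inhibition and lower numbers for stronger inhibition.
Compound 2 `C=C1C[C@]23C[C@@]1(O)CC[C@H]2c1cc(Br)c(O)c(C)c1[C@@H]3Cn1cc(-c2ccccn2)nn1` likewise reaches only the limit > 20000 nM in this assay.
Compound 3 `C=C1C[C@]23C[C@@]1(O)CC[C@H]2c1ccc(O)c(C)c1[C@@H]3Cn1cc(-c2ccccn2)nn1` also reaches only the limit > 20000 nM in this assay.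

Compound 2 therefore stands at the limit of > 20000 nM in this assay, at which 3 of the 3 values shown sit, and no number is known for it. Among the measured compounds shown here, the one change among the measured compounds, from compound 2 to compound 3, gives a step that the two limits leave unreadable from compound 2 to compound 3, so it cannot guide any expectation. Compound 4 `C=C1C[C@]23C[C@@]1(O)CC[C@H]2c1cc(Br)c(O)c(C)c1[C@@H]3Cn1cc(-c2ccc(F)cc2)nn1` differs from compound 2 by 4-fluorophenyl in place of pyridin-2-yl on an aromatic carbon. For the measured compounds named here, no measured step bears on this exchange; compound 1, which carries a different carbon-only ring on the same five-membered ring, also sits at the limit. The step from compound 2 to compound 4 is therefore expected to be a step that the limit leaves unreadable from compound 2 to compound 4, not readable. Compound 4 is estimated at 30000 nM, within 10000 nM to 100000 nM.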

Compound 4, half-maximal inhibitory concentration: 6600 nM
Estimate against measurement, compound 4: 4.5-fold (0.66 log units) above, outside the stated range (below it).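

At this position on the five-membered aromatic ring with 3 nitrogen, the choice of attached ring can change the result in this assay: 4-fluorophenyl in place of pyridin-2-yl gives an at least 3.0-fold lower number from compound 2 to compound 4 (0.48 log units; beyond the scatter). Among the compounds shown here, this is the first readable step, as the step between compound 2 and compound 3 cannot be read. Compound 2 itself has only a limit, not a number: the limit of > 20000 nM in this assay, at which 3 of the 4 values shown sit.

From the compounds shown here alone, it remains open whether the fluorine or the loss of the ring nitrogen accounts for the step, which a plain phenyl group in the same place could separate. Going by these compounds, how an amine or a carboxylic acid on that ring would read is also open.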